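The source may hold more compounds than are shown below. What is called first, only, known or untested is meant among the compounds shown, and "the series" means these compounds.

Measured so far:
compound 1 `Nc1scc(CN2CCN(c3ccc(Cl)c(C(F)(F)F)c3)CC2)c1C(=O)c1ccc(Cl)cc1`: -60%
compound 2 `Nc1scc(CN2CCN(c3ccccc3F)CC2)c1C(=O)c1ccc(Cl)cc1`: -15%

For the measured compounds named here, in a functional assay on CHO cells with adenosine receptor A1 (Homo sapiens) as the target, read by cAMP accumulation and immunoassay, with a stated time of 6 min, tested at 10 uM (on this read-out higher numbers stand for a weaker effect at the one concentration tested and lower numbers for a stronger effect), compound 1 gives -60%, while compound 2 gives -15%, the higher of the two numbers, with compound 1 as its only neighbour well below it. Going by the values given here, the single measured step that concerns the aryl group on the ring nitrogen is a number 45 percentage points higher from compound 1 to compound 2 (beyond the scatter), a large move. Compound 3 `Nc1scc(CN2CCN(c3ccc(F)c(F)c3)CC2)c1C(=O)c1ccc(Cl)cc1` differs from compound 2 by 3,4-difluorophenyl in place of 2-fluorophenyl on an amine nitrogen in a ring. Among the compounds with values here, this exchange again touches only the aryl group on the ring nitrogen, but no measured pair sets 3,4-difluorophenyl against 2-fluorophenyl, so the direction rests on one step only. Compound 1 with 4-chloro-3-(trifluoromethyl)phenyl gave the lower number, and a step of a number 15 percentage points lower from compound 2 to compound 3 (beyond the scatter) is therefore expected, toward a stronger effect, with wide uncertainty. Compound 3 is estimated at -30%, within -60% to 5%.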

Compound 3, a percentage reported as activity, at one concentration (the size of the read-out at that concentration, not a potency): -87%
For compound 3 the middle estimate is 57 percentage points above the measured one; measured number below the stated range.
By their numbers in this assay, from the lowest: compound 3; then compound 1; then compound 2.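

In this assay the aryl group on the ring nitrogen proves more decisive than the earlier step showed: a number 72 percentage points lower from compound 2 to compound 3 (beyond the scatter), and a number 27 percentage points lower from compound 1 to compound 3 (beyond the scatter). Both groups substituted at the 3 and 4 positions of the phenyl ring give lower numbers than 2-fluorophenyl, with no compound shown going against this, yet the two still differ from each other beyond the scatter, so the substituents themselves also count. No evidence on the reason for these steps is available here.

The three compounds leave open whether the loss of the 2-fluoro group or the gain of groups at the 3 and 4 positions drives the step. Plain phenyl, 4-fluorophenyl, or 3-fluorophenyl on the same ring nitrogen would separate these two readings.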